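Chain shortening in the hydroxamic acid series

A few compounds are considered here, and "the series" means these few. Any claim that something is new, unique, unknown or untested is made for them only; others in the source may bear on it.

Measured in a functional assay on A549 cells (Homo sapiens) for antiproliferative activity, read by MTT assay, with a stated time of 96 h; a higher number here means a weaker inhibitor of growth, a lower number a stronger inhibitor of growth
- compound 1 `O=C(CCCCCCNC(=O)c1cc(-c2ccc(F)cc2)[nH]n1)NO` gives 1980 nM
- compound 2 `CCCc1cc(-c2ccc(F)cc2)n(Cc2ccc(C(=O)NO)cc2)n1` gives 16000 nM

Compound 1 holds the lower of the two numbers, and the gap to compound 2 lies beyond the scatter. The next compound to be read is compound 3 `O=C(CCCCCNC(=O)c1cc(-c2ccc(F)cc2)[nH]n1)NO`, which departs from compound 1 at a single place: hydroxycarbamoyl in place of (hydroxycarbamoyl)methyl on a saturated chain carbon, five bonds along the chain from an amide-type nitrogen. Among the compounds with values here, no two measured compounds differ in one place only, so the series offers no direct measure of this change. In this assay a modest rise in the number is expected, of a size close to the scatter. The estimated move is a 1.5-fold higher number from compound 1 to compound 3 (0.18 log units; within the scatter) and remains uncertain. The value expected for compound 3 is 3000 nM with an estimated range of 1200 nM to 8000 nM for now.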

Compound 3, concentration for 50% growth inhibition: 7090 nM
Compound 3: the middle estimate sits 2.4-fold (0.37 log units) below what was measured; the range from low to high includes it.
By their numbers in this assay, from the lowest: compound 1; then compound 3; then compound 2.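

In this assay, within the data shown here, the step from (hydroxycarbamoyl)methyl to hydroxycarbamoyl on a saturated chain carbon, five bonds along the chain from an amide-type nitrogen, gives a 3.6-fold higher number from compound 1 to compound 3 (0.55 log units; beyond the scatter) and is the first direct reading of a single change. The chain carrying the hydroxamic acid is therefore not indifferent to shortening at this place: the shorter chain of compound 3 weakens growth inhibition, and the size of the step lies beyond the scatter. No measurement at hand speaks to the reason for this step.

As far as these compounds go, a single shortening fixes only one direction, so the effect of a longer chain on the core of compound 1 stays open. Also open, from the compounds shown here alone, is whether a carboxylic acid or an amine in place of hydroxycarbamoyl at the chain end would retain any growth inhibition.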